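Adding a Trifluoromethyl to the Benzyl Arm

The source may report more compounds than this note shows. Statements on the series, on what has been measured and on what is new or still open speak of the compounds shown alone.

Measured so far:
Compound 1, `CCCNc1nc(-c2ccccc2)nc2c1nnn2Cc1ccccc1C(F)(F)F`: in an assay on Cerebral cortex for displacement of a labelled ligand from adenosine receptor A1 (Bos taurus) (a higher number here means a weaker inhibitor, a lower number a stronger inhibitor), compound 1 gives "not determined" (no result reported).
Compound 2, `CCCCNc1nc(-c2ccccc2)nc2c1nnn2Cc1ccccc1`: in this assay compound 2 gives 11 nM.

Among the compounds with values here, compound 2 is the only member of this small set with a number attached, so it is the sole point of reference; compound 1 carries a related structure but no result, and the two therefore cannot be compared. The compound to be measured next is compound 3, `CCCCNc1nc(-c2ccccc2)nc2c1nnn2Cc1ccccc1C(F)(F)F`. It keeps the shared core and the butylamino chain of compound 2 and differs from it in one place: trifluoromethyl in place of hydrogen on an aromatic carbon, so that a hydrogen on the benzyl ring is replaced by trifluoromethyl, ortho to a large group. Within the data shown here, no step between two measured compounds is available to say how much such a change has mattered before, so the expectation rests on compound 2 alone. A modest shift in either direction, of a size that may not exceed the usual scatter, is expected in this assay, with the step from compound 2 to compound 3 estimated at a 1.4-fold higher number from compound 2 to compound 3 (0.13 log units; within the scatter). For compound 3 in this assay the expected value is 15 nM, within a range from 4 nM to 60 nM.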

Compound 3, inhibition constant: 6.5 nM
Beside the measured number, compound 3's estimate is 2.3-fold (0.36 log units) above it; low and high end bracket the measured number.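

In this assay, putting trifluoromethyl in place of hydrogen on the benzyl ring, on an aromatic carbon ortho to a large group, gives a 1.7-fold lower number from compound 2 to compound 3 (0.23 log units; within the scatter). Within the data shown here, this is the first reading of this position, which compound 2 alone could not give: with the butylamino chain in place, swapping a single hydrogen for trifluoromethyl at this spot leaves the result indistinguishable from the unsubstituted benzyl compound, and a potent number in the low nanomolar range is kept. Nothing shown here explains why the swap makes so little difference to the result.

As far as these compounds go, one step says little about the position in general, so it remains open whether a methyl, a chlorine, a methoxy group or a carboxylic acid at the same spot would also leave the number in place, and whether trifluoromethyl elsewhere on the benzyl ring would do the same. From the compounds shown here alone, compound 1 has a shorter chain on the amine but no reported result, so the steps that involve it cannot be read, and how chain length and trifluoromethyl work together stays unknown.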